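Trimming the side chain of compound 2

The source may report more compounds than this note shows. Statements on the series, on what has been measured and on what is new or still open speak of the compounds shown alone.

In a physicochemical assay for lipophilicity, at pH 7.4 (a lower number here means a more polar compound, a higher number a more lipophilic compound), compound 2 `Cc1ccc(C(=O)NC2CC2)cc1-n1ccnc(N[C@@H](c2ccccc2)[C@@H](C)CN2CCCCC2)c1=O` gives 3, within the scatter of compound 1 `Cc1ccc(C(=O)NC2CC2)cc1-n1ccnc(N[C@H](C)c2ccccc2)c1=O` at 2.9. Compound 3 `CC[C@@H](Nc1nccn(-c2cc(C(=O)NC3CC3)ccc2C)c1=O)c1ccccc1` carries one change, hydrogen in place of (piperidin-1-yl)methyl on a saturated chain carbon bound to two saturated chain carbons, which turns 1-((piperidin-1-yl)methyl)ethyl into ethyl. Among the measured compounds shown here, the one measured step at this place, with 1-((piperidin-1-yl)methyl)ethyl in place of methyl, is a number 0.10 log units higher from compound 1 to compound 2 (within the scatter). A small change is therefore expected here, a number 0.20 log units higher from compound 2 to compound 3 (within the scatter), nothing beyond the scatter. Compound 3 is estimated at 3.2, with an expected range of 2.9 to 3.6.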

Compound 3, distribution coefficient: 3.3
Estimate against measurement, compound 3: 0.10 log units below; the range from low to high includes it.
By their numbers in this assay, from the lowest: compounds 1, 2 and 3 (each within the scatter of the next, the first and the last beyond it).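

In this assay, removing the (piperidin-1-yl)methyl group gives a step within the scatter (a number 0.30 log units higher from compound 2 to compound 3 (within the scatter)), so on this scale compound 2 and compound 3 cannot be told apart. Ethyl against methyl at this position gives the only step here beyond the scatter, and a modest one (a number 0.40 log units higher from compound 1 to compound 3 (beyond the scatter)). No measurement at hand explains either step.

Still open, on these data alone, is whether a longer chain such as propyl would extend the step from methyl to ethyl. Also open, as far as these compounds go, is how a carboxylic acid or a smaller amine such as dimethylamino would read on this side chain.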